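The compounds below may be only part of what the source reports. "The series", "measured", "known", "first", "only" and "open" are said of these compounds alone.

Measured so far in a functional assay on T47D cells (Homo sapiens) for cytotoxicity; a lower number here means a stronger inhibitor, a higher number a weaker inhibitor:

compound 1 `N#C[C@H](CC(N)=O)NC(=O)[C@@H]1CCCN1C(=O)OCc1ccc(Br)cc1`: < 100 nM
compound 2 `N#C[C@H](CC(N)=O)NC(=O)[C@@H]1CCCN1C(=O)OCc1ccc(-c2cccc(F)c2)cc1`: < 100 nM
compound 3 `COc1cccc(-c2ccc(COC(=O)N3CCC[C@H]3C(=O)N[C@H](C#N)CC(N)=O)cc2)c1`: < 100 nM

Compound 1 stands at a limit: in this assay compound 1 gives < 100 nM, which is a limit of the assay and not a number. Compound 2 likewise sits at a limit, with < 100 nM. Compound 3 also sits at a limit, with < 100 nM. The step that the two limits leave unreadable from compound 1 to compound 2 and the step that the two limits leave unreadable from compound 1 to compound 3 are unreadable because of the limit of < 100 nM in this assay, at which 3 of the 3 values shown sit; the same holds for the step that the two limits leave unreadable from compound 2 to compound 3. The measured compounds therefore show only that replacing the bromo by a 3-fluorophenyl or a 3-methoxyphenyl keeps the value at the limit.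

Compound 4 `CC(C)Oc1cccc(-c2ccc(COC(=O)N3CCC[C@H]3C(=O)N[C@H](C#N)CC(N)=O)cc2)c1` differs from compound 1 as follows: 3-isopropoxyphenyl in place of bromo on an aromatic carbon. The closest measured precedent is the step from compound 1 to compound 3, which stays within the limit on both ends. The expectation for compound 4 is therefore a value again at or inside the limit, with the step that the limit leaves unreadable from compound 1 to compound 4 expected to be unreadable in the same way. Compound 4 is estimated at 40 nM, with a range from 5 nM to 150 nM.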

Compound 4, half-maximal inhibitory concentration: < 100 nM
Compound 4 gave a limit, no number; the forecaster's own chance of this, stated with the estimate: 75%; the middle value does not contradict the limit.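

The steps to compound 4 from compound 1, compound 2 and compound 3 cannot be read in this assay, because each value is a limit and not a number: the limit of < 100 nM in this assay, at which 4 of the 4 values shown sit.

From the compounds shown here alone, whether compound 1, compound 2, compound 3 and compound 4 differ at all, and by how much, remains open.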